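The source may hold more compounds than are shown below. What is called first, only, known or untested is meant among the compounds shown, and "the series" means these compounds.

Among the compounds with values here, compound 1 `COc1ccc(/C=N/NC(=O)Nc2ccc(Oc3ccnc(-c4nncn4CCN(C)C)c3)c(F)c2)c(OC)c1OC` is the only compound with a numerical result in a functional assay on A549 cells (Homo sapiens) for cytotoxicity, read by MTT assay, with a stated time of 72 h (a lower number here means a stronger inhibitor, a higher number a weaker inhibitor), where compound 1 gives 6680 nM. Compound 2 `COc1cc(/C=N/NC(=O)Nc2ccc(Oc3ccnc(-c4nncn4CCN(C)C)c3)c(F)c2)ccc1O` in this assay reaches only a limit, > 100000 nM. Within the data shown here, the sole measured step, an at least 14-fold higher number from compound 1 to compound 2 (1.17 log units; beyond the scatter), exchanged the 2,3,4-trimethoxyphenyl for a 4-hydroxy-3-methoxyphenyl, and it ended at the limit of > 100000 nM in this assay, at which 1 of the 2 values shown sits. Compound 3 `Cc1cc(/C=N/NC(=O)Nc2ccc(Oc3ccnc(-c4nncn4CCN(C)C)c3)c(F)c2)cc(C)c1O` carries a related change at the same place: 4-hydroxy-3,5-dimethylphenyl in place of 2,3,4-trimethoxyphenyl on a carbon with a double bond to nitrogen. The measured step and this one both remove the methoxy groups of the 2,3,4-trimethoxyphenyl and bring in a hydroxyl, so a move in the same direction, toward a higher number, is expected, and a result reported only as a limit is possible. The expected step is a 6.0-fold higher number from compound 1 to compound 3 (0.78 log units; beyond the scatter). For compound 3 the estimate in this assay is 40000 nM, with a range from 10000 nM to 150000 nM.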

Compound 3, half-maximal inhibitory concentration: 1640 nM
The estimate for compound 3 lay 24-fold (1.39 log units) above the measured number; the measured number lies below the stated range.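

In this assay a hydroxyl on the aromatic ring at this place does not by itself bring a higher number: the exchange of 2,3,4-trimethoxyphenyl for 4-hydroxy-3,5-dimethylphenyl gives a 4.1-fold lower number from compound 1 to compound 3 (0.61 log units; beyond the scatter). Between the two hydroxyl-bearing groups, 4-hydroxy-3,5-dimethylphenyl in place of 4-hydroxy-3-methoxyphenyl gives an at least 60-fold lower number from compound 2 to compound 3 (1.78 log units; beyond the scatter), so the outcome here depends on what accompanies the hydroxyl and not on the hydroxyl alone. The starting value of compound 2 is a limit and not a number, so that step has no exact size: the limit of > 100000 nM in this assay, at which 1 of the 3 values shown sits.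

The compounds shown do not separate the contribution of the hydroxyl from that of the two methyl groups, a question that a 4-methoxy-3,5-dimethylphenyl group would address. As far as these compounds go, whether ethyl groups or chlorine atoms could stand in for those methyl groups also remains open.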